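Aminomethyl replaces nitro on the pyridine of compound 3

A few compounds are considered here, and "the series" means these few. Any claim that something is new, unique, unknown or untested is made for them only; others in the source may bear on it.

In an assay on brain for binding affinity to Neuronal acetylcholine receptor; alpha4/beta2 (Rattus norvegicus), read by radioligand binding (on this read-out lower numbers stand for stronger inhibition and higher numbers for weaker inhibition), compound 1 `Clc1cncc(OC[C@@H]2CCN2)c1` gives 0.042 nM, compound 2 `CCc1cncc(OC[C@@H]2CCN2)c1` gives 0.1 nM, and compound 3 `O=[N+]([O-])c1cncc(OC[C@@H]2CCN2)c1` gives 0.33 nM, the highest of the three numbers. The steps of a 7.9-fold higher number from compound 1 to compound 3 (0.90 log units; beyond the scatter) and a 3.3-fold higher number from compound 2 to compound 3 (0.52 log units; beyond the scatter) show that nitro at this aromatic carbon weakens binding modestly against chloro or ethyl, while a 2.4-fold higher number from compound 1 to compound 2 (0.38 log units; beyond the scatter) is smaller. Compound 4 `NCc1cncc(OC[C@@H]2CCN2)c1` differs from compound 3 by aminomethyl in place of nitro on an aromatic carbon, on a ring atom two atoms from the ring nitrogen and meta to a group of 6 heavy atoms. Going by the values given here, no measured step covers aminomethyl, so the direction is uncertain; a further modest weakening beyond the scatter is expected, with a 3.0-fold higher number from compound 3 to compound 4 (0.48 log units; beyond the scatter) as the estimated step. Compound 4 is therefore expected to give about 1 nM, within 0.2 nM to 5 nM.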

Compound 4, inhibition constant: 4.4 nM
Compound 4: the middle estimate sits 4.4-fold (0.64 log units) below what was measured, within the range that was stated.
By their numbers in this assay, from the lowest: compound 1; then compound 2; then compound 3; then compound 4.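

In this assay, aminomethyl at this aromatic carbon, two atoms from the ring nitrogen, costs far more than any earlier change, with a large step from nitro (a 13-fold higher number from compound 3 to compound 4 (1.12 log units; beyond the scatter)) and from chloro (a 100-fold higher number from compound 1 to compound 4 (2.02 log units; beyond the scatter)). Amino in place of methyl on the saturated chain carbon is enough to produce a large step (a 44-fold higher number from compound 2 to compound 4 (1.64 log units; beyond the scatter)), whereas chloro, ethyl and nitro differed only modestly. Nothing shown here explains this loss. Open, from the compounds shown here alone, is whether a hydroxymethyl or a dimethylaminomethyl group at this carbon would behave like ethyl or like aminomethyl.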